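Chain-end aryl swap from compound 3 to compound 4

The compounds below may be only part of what the source reports. "The series", "measured", "known", "first", "only" and "open" are said of these compounds alone.

Three compounds sharing one core have numbers in a functional assay on MCF7 cells (Homo sapiens) for cytotoxicity; on this read-out lower numbers stand for stronger inhibition and higher numbers for weaker inhibition. Compound 1 `C=C/C=C\[C@H](C)[C@H](OC(N)=O)[C@@H](C)[C@H](O)[C@@H](C)C/C(C)=C\[C@H](C)[C@@H](O)[C@@H](C)/C=C\CCc1ccc(C)c(F)c1` gives 4000 nM, compound 2 `C=C/C=C\[C@H](C)[C@H](OC(N)=O)[C@@H](C)[C@H](O)[C@@H](C)C/C(C)=C\[C@H](C)[C@@H](O)[C@@H](C)/C=C\CCc1cccc(F)c1` gives 500 nM and compound 3 `C=C/C=C\[C@H](C)[C@H](OC(N)=O)[C@@H](C)[C@H](O)[C@@H](C)C/C(C)=C\[C@H](C)[C@@H](O)[C@@H](C)/C=C\CCc1sccc1C` gives 620 nM. Compound 3 therefore stands level with compound 2 and clearly lower than compound 1, with a 6.5-fold lower number from compound 1 to compound 3 (0.81 log units; beyond the scatter).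

Compound 4 `C=C/C=C\[C@H](C)[C@H](OC(N)=O)[C@@H](C)[C@H](O)[C@@H](C)C/C(C)=C\[C@H](C)[C@@H](O)[C@@H](C)/C=C\CCc1cccc(O)c1` is the next entry. Its difference from compound 3 is 3-hydroxyphenyl in place of 3-methylthiophen-2-yl on a saturated chain carbon, two bonds along the chain from a double-bonded chain carbon.

Among the measured compounds shown here, no measured compound carries a hydroxy group on this ring, so the evidence is indirect. For the measured compounds named here, the closest precedent is the exchange between 3-fluorophenyl and 3-methylthiophen-2-yl, with a 1.2-fold higher number from compound 2 to compound 3 (0.09 log units; within the scatter), which stays within the scatter. Against this, an 8.0-fold lower number from compound 1 to compound 2 (0.90 log units; beyond the scatter) goes beyond the scatter and shows that a single small change on the ring can matter in this assay, so a wide range is kept. No step beyond the scatter is expected, and the expected step is a 1.1-fold higher number from compound 3 to compound 4 (0.05 log units; within the scatter). For compound 4 the estimated value is 700 nM, with an expected range of 250 nM to 2500 nM.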

Compound 4, half-maximal inhibitory concentration: 390 nM
Estimate against measurement, compound 4: 1.8-fold (0.25 log units) above; the measured number falls inside the stated range.
By their numbers in this assay, from the lowest: compounds 4, 2 and 3 (each within the scatter of the next); then compound 1.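

In this assay, the chain-end ring at this position accommodates a hydrogen-bond donor without a step beyond the scatter: 3-hydroxyphenyl, unlike 3-methylthiophen-2-yl, carries one, yet the exchange gives a 1.6-fold lower number from compound 3 to compound 4 (0.20 log units; within the scatter), and hydroxy in place of fluoro on the aromatic carbon gives a 1.3-fold lower number from compound 2 to compound 4 (0.11 log units; within the scatter). Compounds 2, 3 and 4 therefore form a level group despite their different rings and ring substituents, while compound 1 stands apart with its 3-fluoro-4-methylphenyl group, and a 10-fold lower number from compound 1 to compound 4 (1.01 log units; beyond the scatter) is the largest step in the set, although compound 3 also has a methyl on its ring and stays in the level group. Nothing available on these compounds accounts for this grouping or for the separate place of compound 1.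

Still open, as far as these compounds go, is whether an amine or a carboxylic acid on this ring, or a longer chain leading to it, would remain level with compounds 2, 3 and 4. From the compounds shown here alone, it is also open whether the methyl that separates compound 1 from compound 2 would have a step of similar size if the ring carried hydroxy in place of fluoro.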